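The compounds below may be only part of what the source reports. "The series", "measured", "known", "first", "only" and "open" are said of these compounds alone.

Measured so far in an ADME assay for permeability; on this read-out higher numbers stand for higher permeability and lower numbers for lower permeability:
compound 1 `CNC(=O)c1cc(C(=O)N[C@H]2CC[C@H](O)CC2)c([C@@H](C)c2cccc(Cl)c2)o1`: 150 nm/s
compound 2 `CCCNC(=O)c1cc(C(=O)NC)nn1[C@@H](C)c1ccccc1`: 560 nm/s
compound 3 `CNC(=O)c1cc(C(=O)NC2CC2)cn(Cc2cccc3[nH]ccc23)c1=O`: 178 nm/s

On this read-out compound 1 at 150 nm/s lies within the scatter of compound 3 at 178 nm/s. Compound 2 stands at 560 nm/s, and compound 1 and compound 3 both lie lower by more than the scatter.

Not yet measured is compound 4 `CNC(=O)c1cc(C(=O)N[C@H]2CC[C@H](O)CC2)c([C@@H](C)c2ccccc2Cl)o1`, which keeps the core of compound 1 and differs in one place: 2-chlorophenyl in place of 3-chlorophenyl on a saturated chain carbon bound to an aromatic carbon and a saturated chain carbon. It carries 2-chlorophenyl in place of 3-chlorophenyl on a saturated chain carbon bound to an aromatic carbon and a saturated chain carbon. Going by the values given here, the measured compounds offer no pair that differs in one place, so the data give no direct guide to this change. The two structures have the same atoms, joined differently, and no step beyond the scatter is expected in this assay. The expectation therefore stays close to compound 1 at 150 nm/s and the direction is left open. The estimated change is a 1.1-fold higher number from compound 1 to compound 4 (0.04 log units; within the scatter) and it is expected to stay within the scatter. For compound 4 the estimated value is 165 nm/s with an expected range of 85 nm/s to 310 nm/s around it.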

Compound 4, apparent permeability: 78 nm/s
Beside the measured number, compound 4's estimate is 2.1-fold (0.33 log units) above it; measured number below the stated range.
By their numbers in this assay, from the lowest: compounds 4, 1 and 3 (each within the scatter of the next, the first and the last beyond it); then compound 2.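

In this assay, going by these compounds alone, this is the first step that can be read at a single place: 2-chlorophenyl in place of 3-chlorophenyl on a saturated chain carbon bound to an aromatic carbon and a saturated chain carbon gives a 1.9-fold lower number from compound 1 to compound 4 (0.28 log units; within the scatter) on the core of compound 1. At this place, then, the two chlorophenyl groups are not separated by this assay, though this rests on one pair alone. No supporting measurement bears on this step, so the result stands without an explanation.

On these data alone, whether any group at this place gives a step beyond the scatter remains open, for instance 4-chlorophenyl or a phenyl carrying a carboxylic acid. Also open, as far as these compounds go, is whether the same exchange gives a similar step on the cores of compound 2 or compound 3.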